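This account rests on a few compounds, and the source may have more. Where it says the series, first, only, none or still open, it means among the compounds named here.

Compound 1 `CN(C)CCNc1nc(-c2ccc(NC(=O)Nc3ccc(Cl)cc3Cl)cc2)nc2ccsc12`, 1320 nM
Compound 2 `CCN(CC)CCNc1nc(-c2ccc(NC(=O)Nc3ccccc3F)cc2)nc2ccsc12`, 610 nM

In a functional assay on HT-29 cells (Homo sapiens) for cytotoxicity, read by MTT assay, with a stated time of 72 h (on this read-out higher numbers stand for weaker inhibition and lower numbers for stronger inhibition), compound 2 gives 610 nM, the lowest of the two numbers; compound 1 gives 1320 nM, a higher number by a step that lies beyond the usual scatter. Compound 3 `CCN(CC)CCNc1nc(-c2ccc(NC(=O)Nc3ccc(Cl)cc3Cl)cc2)nc2ccsc12` has not yet been measured. It is reached from compound 2 by one change: 2,4-dichlorophenyl in place of 2-fluorophenyl on an amide-type nitrogen. Among the measured compounds shown here, no measured pair shows this change on its own, so its size can only be guessed. Compound 1 also bears the 2,4-dichlorophenyl on its amide-type nitrogen and sits at the higher end of the two numbers, which gives mild reason to expect compound 3 to move toward higher numbers, by a step near the edge of the scatter, a 1.6-fold higher number from compound 2 to compound 3 (0.21 log units; within the scatter). Compound 3 is therefore estimated at 1000 nM in this assay, with a range from 400 nM to 2500 nM.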

Compound 3, half-maximal inhibitory concentration: 1940 nM
Estimate against measurement, compound 3: 1.9-fold (0.29 log units) below; measured number inside the range.
By their numbers in this assay, from the lowest: compound 2; then compounds 1 and 3 (each within the scatter of the next).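

In this assay, 2,4-dichlorophenyl in place of 2-fluorophenyl on the amide-type nitrogen gives a 3.2-fold higher number from compound 2 to compound 3 (0.50 log units; beyond the scatter), so this position now has a step read directly, and it lies beyond the usual scatter. Diethylamino in place of dimethylamino on the saturated chain carbon gives a 1.5-fold higher number from compound 1 to compound 3 (0.17 log units; within the scatter), so with 2,4-dichlorophenyl on the amide-type nitrogen, these two amines are not told apart in this assay. Nothing measured here explains either step.

The compounds shown leave open whether the aryl step would keep its size with dimethylamino on the chain, and whether one chlorine alone would give it, as a 2-chlorophenyl or 4-chlorophenyl group could show. They also leave open how a ring amine such as morpholine or piperidine would compare with diethylamino and dimethylamino.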